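Chloro for Fluoro on a Shared Core: Two Measured, One Pending

A few compounds are considered here, and "the series" means these few. Any claim that something is new, unique, unknown or untested is made for them only; others in the source may bear on it.

compound 1 `CCc1ccc(NC2=CC(=O)c3c(nc4n3[C@H]3OC[C@@H](O)[C@H]3OC4)C2=O)cc1` — 6510 nM
compound 2 `O=C1C=C(Nc2cccc(F)c2)C(=O)c2c1nc1n2[C@H]2OC[C@@H](O)[C@H]2OC1` — 6440 nM

In a functional assay on HeLa cells (Homo sapiens) for inhibition, read by sulforhodamine B assay (a higher number here means a weaker inhibitor, a lower number a stronger inhibitor), compound 1 gives 6510 nM. In this assay compound 2 gives 6440 nM. Within the data shown here, these two numbers lie within the usual scatter of each other, so no order between compound 1 and compound 2 can be read from them; they differ in more than one place, and no single step is recorded between them.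

Compound 3 `O=C1C=C(Nc2cccc(Cl)c2)C(=O)c2c1nc1n2[C@H]2OC[C@@H](O)[C@H]2OC1` differs from compound 2 in one place: chloro in place of fluoro on an aromatic carbon. Among the measured compounds shown here, no measured pair isolates this change, so the expectation rests on the two numbers above alone. The step from compound 2 to compound 3 is expected to be small, about a 1.3-fold lower number from compound 2 to compound 3 (0.11 log units; within the scatter), with no clear direction beyond the scatter. Compound 3 is therefore estimated at 5000 nM in this assay, within a range of 2000 nM to 12000 nM.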

Compound 3, half-maximal inhibitory concentration: 6040 nM
The estimate for compound 3 lay 1.2-fold (0.08 log units) below the measured number; measured number inside the range.
By their numbers in this assay, from the lowest: compounds 3, 2 and 1 (each within the scatter of the next).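

Compound 3 gives the only single-place comparison shown in this series: in this assay, 3-fluorophenyl to 3-chlorophenyl on the shared core reads as a 1.1-fold lower number from compound 2 to compound 3 (0.03 log units; within the scatter). On this aromatic carbon, meta to a large group, fluoro and chloro therefore cannot be told apart in this read-out. Nothing measured here speaks to a reason for this result.

On these data alone, whether this position responds to anything other than these two halogens stays open, for instance an amine, a carboxylic acid or a methoxy group in the same place. Compound 1 differs from compound 2 and compound 3 in more than one place, so the contribution of its ethyl group cannot be separated from the other difference.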